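The compounds below may be only part of what the source reports. "The series", "measured", "known", "first", "only" and "open" are said of these compounds alone.

Measured compounds:
Compound 1, `CN(C)c1ccc(Nc2nccc(-c3cccs3)n2)cc1`: 900 nM
Compound 2, `Cc1cccc(Nc2nccc(-c3ccc[nH]3)n2)c1`: 8500 nM
Compound 3, `CCOC(=O)c1cccc(Nc2nccc(-c3ccccn3)n2)c1`: 3000 nM

Three compounds sharing one core were tested in a functional assay for inhibition, with Homo sapiens as the target; on this read-out higher numbers stand for weaker inhibition and lower numbers for stronger inhibition. Compound 2 stands at the highest number of the three, that is, it is the weakest inhibitor here; compound 3 gives 3000 nM and compound 1 gives 900 nM, and both of these gaps to compound 2 lie beyond the usual scatter. The three compounds differ from one another in more than one place, so none of these gaps can be traced to a single change.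

Compound 4, `Cc1cccc(Nc2nccc(-c3ccsc3)n2)c1`, has not yet been measured. It differs from compound 2 in one place only: thiophen-3-yl in place of 1H-pyrrol-2-yl on an aromatic carbon. Among the compounds with values here, no pair of measured compounds shows this change on its own. Compound 1 also carries a sulfur-containing five-membered ring on its core, but it differs from compound 2 at the aniline part as well, so its number cannot be read as the effect of the ring alone. On that basis only a modest step is expected, toward a lower number, and it may well fall within the scatter. Compound 4 is therefore estimated at 4000 nM, with a range from 1200 nM to 13000 nM. This expectation corresponds to a 2.1-fold lower number from compound 2 to compound 4 (0.33 log units; beyond the scatter).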

Compound 4, half-maximal inhibitory concentration: 3800 nM
Estimate against measurement, compound 4: 1.1-fold (0.02 log units) above, and the stated range covers the measured number.
By their numbers in this assay, from the lowest: compound 1; then compounds 3 and 4 (each within the scatter of the next); then compound 2.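

In this assay, thiophen-3-yl in place of 1H-pyrrol-2-yl, on the aromatic carbon next to the ring nitrogen, gives a 2.2-fold lower number from compound 2 to compound 4 (0.35 log units; beyond the scatter). Within the data shown here, this is the first change in the set that can be read at a single place, and it is modest but beyond the scatter. The group that leaves carries a hydrogen-bond donor and the group that enters carries none, yet with the same count of heavy atoms the number does not rise, so on the background of compound 2 that donor is not required to keep this level of inhibition. Nothing given here accounts for the size or the direction of this step.

Open, from the compounds shown here alone, is whether the gain belongs to the sulfur ring itself or to the loss of the donor, which a 1-methylpyrrol-2-yl group or a furan-3-yl group at the same carbon would help to separate. Going by these compounds, compound 1 and compound 3 each differ from compound 4 in more than one place, so it also stays open whether thiophen-3-yl would give a similar step with a dimethylamino group or an ethyl ester on the aniline part.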